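A few compounds are considered here, and "the series" means these few. Any claim that something is new, unique, unknown or untested is made for them only; others in the source may bear on it.

Of the compounds shown here, three sharing one core have been measured in an assay on isolated protein for inhibition of aldehyde dehydrogenase 1A1 (Homo sapiens), read by spectrophotometry, tested at 10 uM; a lower number here means less inhibition, a higher number more inhibition at the concentration tested (going by the name of the read-out). Compound 1 `Cc1cccc(Cn2c(CN3CCN(C(=O)c4ccc(C(C)C)cc4)CC3)nc3ccccc32)c1` gives 67.6% in this assay. Compound 2 `Cc1cccc(Cn2c(CN3CCN(C(=O)CC(C)C)CC3)nc3ccccc32)c1` gives 71.4%, and the step of a number 3.8 percentage points higher from compound 1 to compound 2 (within the scatter) shows no difference of note. Compound 3 `Cc1cccc(Cn2c(CN3CCN(C(=O)c4ccc(C#N)cc4)CC3)nc3ccccc32)c1` gives 20.8% in this assay, the lowest of the three numbers, with compound 1 nearest and compound 2 furthest, both gaps beyond the scatter. The step of a number 46.8 percentage points lower from compound 1 to compound 3 (beyond the scatter) was large.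

Compound 4 `Cc1cccc(Cn2c(CN3CCN(C(=O)C4CCC4)CC3)nc3ccccc32)c1` has not yet been measured. It differs from compound 3 in this way: cyclobutyl in place of 4-cyanophenyl on a carbonyl carbon. The step that bears most on this change is a number 50.6 percentage points lower from compound 2 to compound 3 (beyond the scatter), in which isobutyl was exchanged for the 4-cyanophenyl group that now leaves; the step of a number 3.8 percentage points higher from compound 1 to compound 2 (within the scatter), by contrast, changed little. Removing the 4-cyanophenyl group in favour of a small saturated ring is therefore expected to bring a large step upward in this assay, a number 44.2 percentage points higher from compound 3 to compound 4 (beyond the scatter). Compound 4 is expected to give about 65% in this assay, within a range from 45% to 82%.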

Compound 4, a percentage reported as inhibition, at one concentration (the size of the read-out at that concentration, not a potency): 69.1%
Compound 4: middle estimate off by 4.1 percentage points, on the low side; the measured number falls inside the stated range.
By their numbers in this assay, from the lowest: compound 3; then compounds 1, 4 and 2 (each within the scatter of the next).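

Cyclobutyl on the carbonyl carbon reads alike with the two groups that earlier held the number up in this assay: the comparison gives a number 2.3 percentage points lower from compound 2 to compound 4 (within the scatter) against isobutyl and a number 1.5 percentage points higher from compound 1 to compound 4 (within the scatter) against 4-isopropylphenyl. The step of a number 48.3 percentage points higher from compound 3 to compound 4 (beyond the scatter) thus sets a small saturated ring against 4-cyanophenyl and leaves compound 3 alone apart from a ring, an open chain and a differently substituted phenyl group. No measurement offered here explains this difference.

Going by these compounds, it remains open whether the low number of compound 3 follows the nitrile alone, or whether an amine or a carboxylic acid on the same aromatic carbon would read likewise. Nor do these compounds show how a longer chain on the carbonyl carbon would read.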